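Compound 4: dimethylamino in place of nitro

The source may report more compounds than this note shows. Statements on the series, on what has been measured and on what is new or still open speak of the compounds shown alone.

Compound 3 `O=C(c1ccc([N+](=O)[O-])cc1)N1CCC(n2cncc2-c2ccc(OS(=O)(=O)c3cccc4cnccc34)cc2)CC1` holds the lowest number of the three measured: in an assay on HEK293 cells for antagonist activity at P2X purinoceptor 7 (Homo sapiens), read by fluorescence, with a stated time of 2 h (a higher number here means a weaker inhibitor, a lower number a stronger inhibitor), compound 3 gives 1.49 nM. Compound 1 `COc1ccc(C(=O)N2CCC(n3cncc3-c3ccc(OS(=O)(=O)c4cccc5cnccc45)cc3)CC2)cc1` gives 77 nM and compound 2 `O=C(c1ccc(Oc2ccccc2)cc1)N1CCC(n2cncc2-c2ccc(OS(=O)(=O)c3cccc4cnccc34)cc2)CC1` gives 187 nM. The steps of a 52-fold lower number from compound 1 to compound 3 (1.71 log units; beyond the scatter) and a 130-fold lower number from compound 2 to compound 3 (2.10 log units; beyond the scatter) both put the nitro group far ahead of methoxy and phenoxy at the same place. Compound 4 `CN(C)c1ccc(C(=O)N2CCC(n3cncc3-c3ccc(OS(=O)(=O)c4cccc5cnccc45)cc3)CC2)cc1` carries the change (dimethylamino in place of nitro on an aromatic carbon). For the measured compounds named here, no measured step involves dimethylamino, so the expectation rests on the two steps into nitro; both were large, and removing the nitro is expected to undo much of that gain, giving a large rise in number, a 40-fold higher number from compound 3 to compound 4 (1.60 log units; beyond the scatter). Compound 4 is therefore estimated at 60 nM, with a range of 10 nM to 300 nM.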

Compound 4, half-maximal inhibitory concentration: 0.11 nM
For compound 4 the middle estimate is 550-fold (2.74 log units) above the measured one, and the stated range ends above it.
By their numbers in this assay, from the lowest: compound 4; then compound 3; then compound 1; then compound 2.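

Dimethylamino shows that nitro is not the limit at this place, para to a large group, in this assay: the series goes further with a 14-fold lower number from compound 3 to compound 4 (1.13 log units; beyond the scatter) as the step. The distance from the groups joined through oxygen is wide, with a 700-fold lower number from compound 1 to compound 4 (2.85 log units; beyond the scatter) for methoxy and a 1700-fold lower number from compound 2 to compound 4 (3.23 log units; beyond the scatter) for phenoxy, and among the four compounds both groups joined through nitrogen give lower numbers than both groups joined through oxygen. No measurement at hand accounts for this order. On these data alone, whether a primary amine, methylamino or a pyrrolidine ring at this place would keep so low a number stays open.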